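Methoxy position shift across two acid series

The source may report more compounds than this note shows. Statements on the series, on what has been measured and on what is new or still open speak of the compounds shown alone.

Measured so far:
compound 1 `COc1ccccc1-c1nc(C)c(COc2ccccc2C(=O)O)o1` — in an assay on cells for antagonist activity at vitamin D3 receptor (Homo sapiens), read by a luciferase reporter (on this read-out lower numbers stand for stronger inhibition and higher numbers for weaker inhibition), compound 1 gives > 80000 nM, which is a limit of the assay rather than a number.
compound 2 `COc1cccc(-c2nc(C)c(COc3ccccc3C(=O)O)o2)c1` — in this assay compound 2 gives > 33000 nM, likewise a limit.
compound 3 `COc1ccccc1-c1nc(C)c(COc2ccc(CCC(=O)O)cc2)o1` — in this assay compound 3 gives > 100000 nM, again a limit.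

Compounds 1 and 2 differ by 3-methoxyphenyl in place of 2-methoxyphenyl on an aromatic carbon. The step that the two limits leave unreadable from compound 1 to compound 2 cannot be sized because compound 1 sits at the limit of > 80000 nM in this assay, at which 1 of the 3 values shown sits, and compound 2 sits at the limit of > 33000 nM in this assay, at which 1 of the 3 values shown sits. The difference between the core of compound 1 and the core of compound 3 is not broken down here.

Compound 4 `COc1cccc(-c2nc(C)c(COc3ccc(CCC(=O)O)cc3)o2)c1` carries the same change as compound 2, namely (3-methoxyphenyl in place of 2-methoxyphenyl on an aromatic carbon); the place is the same word for word. Compound 3 sits at the limit of > 100000 nM in this assay, at which 1 of the 3 values shown sits. On that basis the step that the limit leaves unreadable from compound 3 to compound 4 is expected, with no readable change. Compound 4 is estimated at 150000 nM, within a range from 30000 nM to 1000000 nM.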

Compound 4, half-maximal inhibitory concentration: 26700 nM
Compound 4: middle estimate off by 5.6-fold (0.75 log units), on the high side, and the stated range ends above it.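

In this assay, going by these compounds alone, 3-methoxyphenyl in place of 2-methoxyphenyl gives an at least 3.7-fold lower number from compound 3 to compound 4 (0.57 log units; beyond the scatter), the only readable step for this change. Compound 3 gives > 100000 nM, a limit of the assay, so this step sets a minimum and not a size. The same change on the core of compound 1 cannot be read, as compound 1 and compound 2 both stand at limits, so the result on the core of compound 3 is not shown to carry over to the other core.

As far as these compounds go, it remains open whether compound 4, at 26700 nM, would hold that number with an ethoxy group in place of the methoxy group. The same question stands for a tetrazole in place of the carboxylic acid.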